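The source may hold more compounds than are shown below. What is called first, only, known or untested is meant among the compounds shown, and "the series" means these compounds.

Of the compounds shown here, three built on one shared core have been measured in an assay on cells for agonist activity at ecdysone receptor (Bombyx mori), read by a luciferase reporter, with a stated time of 24 h; on this read-out lower numbers stand for an effect already at smaller amounts and higher numbers for an effect only at larger amounts of compound. Compound 1 `CC(C)(C)N(NC(=O)c1ccccc1Br)C(=O)c1ccccc1Cl` gives 316 nM, compound 2 `CC(C)(C)N(NC(=O)c1ccc(C#N)cc1)C(=O)c1ccccc1Cl` gives 603 nM, and compound 3 `CCc1ccc(C(=O)NN(C(=O)c2ccccc2Cl)C(C)(C)C)cc1` gives 5.75 nM. Compound 3 stands lowest of the three: the step of a 55-fold lower number from compound 1 to compound 3 (1.74 log units; beyond the scatter) and the step of a 100-fold lower number from compound 2 to compound 3 (2.02 log units; beyond the scatter) both lie beyond the scatter, whereas a 1.9-fold higher number from compound 1 to compound 2 (0.28 log units; within the scatter) does not.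

Compound 4 `CCCCCCC(=O)NN(C(=O)c1ccccc1Cl)C(C)(C)C` differs from compound 3 in one place: hexyl in place of 4-ethylphenyl on a carbonyl carbon. A group of eight heavy atoms with one six-membered aromatic ring of carbon only leaves, and a chain of six heavy atoms with no ring enters on the carbonyl carbon whose other neighbour is an amide-type nitrogen.

Among the measured compounds shown here, none of the measured steps removes the aromatic ring at this carbonyl carbon, so no step bears directly on the change. The measured steps do show that this position is sensitive, since changing only the aryl group or its substituent produced a 55-fold lower number from compound 1 to compound 3 (1.74 log units; beyond the scatter) and a 100-fold lower number from compound 2 to compound 3 (2.02 log units; beyond the scatter). Because a 100-fold lower number from compound 2 to compound 3 (2.02 log units; beyond the scatter) was large for a change far smaller than this one, a large step upward in this assay is expected, a 52-fold higher number from compound 3 to compound 4 (1.72 log units; beyond the scatter). Compound 4 is therefore estimated at 300 nM, with a range from 30 nM to 3000 nM.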

Compound 4, half-maximal effective concentration: 741 nM
Beside the measured number, compound 4's estimate is 2.5-fold (0.39 log units) below it; the range from low to high includes it.
By their numbers in this assay, from the lowest: compound 3; then compounds 1, 2 and 4 (each within the scatter of the next, the first and the last beyond it).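

In this assay, replacing the aromatic ring on this carbonyl carbon with an open chain can cost a great deal, as hexyl in place of 4-ethylphenyl gives a 130-fold higher number from compound 3 to compound 4 (2.11 log units; beyond the scatter). Yet the ring alone does not set the low number: hexyl in place of 4-cyanophenyl gives a 1.2-fold higher number from compound 2 to compound 4 (0.09 log units; within the scatter), which is within the scatter, and hexyl in place of 2-bromophenyl gives only a 2.3-fold higher number from compound 1 to compound 4 (0.37 log units; beyond the scatter), so compound 1 and compound 2 go against any rule that an aromatic ring here ensures a low number. Among these four compounds, the low number at this position belongs to the 4-ethylphenyl group of compound 3 alone, and nothing given here accounts for that.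

From the compounds shown here alone, it remains open whether a shorter chain such as butyl, a longer chain such as octyl, or a saturated ring such as cyclohexyl would stand nearer to compound 3 or to compound 4. Going by these compounds, it is also open how an amine or a carboxylic acid carried on the hexyl chain would change the number.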